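A few compounds are considered here, and "the series" means these few. Any claim that something is new, unique, unknown or untested is made for them only; others in the source may bear on it.

Of the compounds shown here, three have been measured in an assay on membranes from uterus for displacement of a labelled ligand from Angiotensin type II receptor (Sus scrofa), with a stated time of 1.5 h; on this read-out higher numbers stand for weaker inhibition and lower numbers for stronger inhibition.
Compound 1, `CCCCOC(=O)NS(=O)(=O)c1sc(CC(C)C)cc1-c1ccc(Cc2nccs2)cc1`, gives 3.2 nM.
Compound 2, `CCCCOC(=O)NS(=O)(=O)c1sc(CC(C)C)cc1-c1ccc(Cn2cccn2)cc1`, gives 2.3 nM.
Compound 3, `CCCCOC(=O)NS(=O)(=O)c1sc(CC(C)C)cc1-c1ccc(Cn2cnc(C(F)(F)F)c2)cc1`, gives 7.3 nM.

Among these three, compound 3 has the highest number, that is the weakest binding. Its nearest neighbour is compound 1, with the step of a 2.3-fold higher number from compound 1 to compound 3 (0.36 log units; beyond the scatter); the gap to compound 2 is wider, a 3.2-fold higher number from compound 2 to compound 3 (0.50 log units; beyond the scatter). Compound 1 and compound 2 lie within the scatter of each other, a 1.4-fold lower number from compound 1 to compound 2 (0.14 log units; within the scatter), so no order between them is claimed.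

Compound 4, `CCCCOC(=O)NS(=O)(=O)c1sc(CC(C)C)cc1-c1ccc(C(=O)c2nccs2)cc1`, has not yet been measured. Relative to compound 3 the change is a group of 7 heavy atoms (4 carbon, 1 nitrogen, 1 oxygen, 1 sulfur; one five-membered aromatic ring with 2 hetero atoms) in place of a group of 10 heavy atoms (5 carbon, 2 nitrogen, 3 fluorine; one five-membered aromatic ring with 2 hetero atoms), on an aromatic carbon. This brings back the same five-membered ring that compound 1 carries, but joined through a carbonyl rather than a saturated chain carbon. The step of a 2.3-fold higher number from compound 1 to compound 3 (0.36 log units; beyond the scatter) bears on it most directly, read in reverse, and a 3.2-fold higher number from compound 2 to compound 3 (0.50 log units; beyond the scatter) points the same way; both were modest. For the measured compounds named here, the carbonyl link itself has no measured counterpart here, so the range is kept wide. The expected step is a 1.8-fold lower number from compound 3 to compound 4 (0.26 log units; within the scatter), a modest move toward a lower number. Compound 4 is therefore estimated at 4 nM, with a range from 1.5 nM to 15 nM.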

Compound 4, inhibition constant: 18.6 nM
For compound 4 the middle estimate is 4.7-fold (0.67 log units) below the measured one; the measured number lies above the stated range.
By their numbers in this assay, from the lowest: compounds 2 and 1 (each within the scatter of the next); then compound 3; then compound 4.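

The clearest reading comes from the pair that keeps the 1,3-thiazol-2-yl ring and changes only its link to the shared core: in this assay, a carbonyl in place of the saturated chain carbon gives a 5.8-fold higher number from compound 1 to compound 4 (0.76 log units; beyond the scatter), so at this position the link matters as well as the ring it carries. The earlier compounds shown here varied only the ring, always on a saturated chain carbon, and none of their steps was as large as this one or as an 8.1-fold higher number from compound 2 to compound 4 (0.91 log units; beyond the scatter), which changes ring and link together. The new compound also has a higher number than the trifluoromethyl-bearing compound, with a 2.5-fold higher number from compound 3 to compound 4 (0.41 log units; beyond the scatter), so restoring the thiazole ring does not make up for the change of link.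

Nothing available on these compounds explains why the carbonyl link gives weaker binding. As far as these compounds go, it also remains open whether this shift belongs to the carbonyl alone or to its pairing with this ring: a carbonyl carrying a 1H-pyrazol-1-yl ring, or a link with a hydroxyl group on the chain carbon or a single ether oxygen, would help separate these possibilities.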